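The source may report more compounds than this note shows. Statements on the series, on what has been measured and on what is new or still open speak of the compounds shown alone.

So far, two compounds that share one core have been measured. In a functional assay (muscle tissue) with Cavia porcellus as the target (a higher number here means that more compound is needed for the effect, a lower number that less compound is needed), compound 1 `COC(=O)C1=C(C)N=C(C)/C(=C(\O)OC)C1c1ccccc1Cl` gives 2.19 nM, while compound 2 `CCc1ccccc1C1C(C(=O)OC)=C(C)N=C(C)/C1=C(\O)OC` gives 6.46 nM, the higher of the two numbers. Compound 3 `COC(=O)C1=C(C)N=C(C)/C(=C(\O)OC)C1c1ccc(Br)cc1` keeps the shared core but carries a different aromatic group: 4-bromophenyl in place of 2-ethylphenyl on a saturated ring carbon. Put simply, 4-bromophenyl takes the place of 2-ethylphenyl on a saturated ring carbon.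

Going by the values given here, only one measured step bears on this change. It is a 2.9-fold higher number from compound 1 to compound 2 (0.47 log units; beyond the scatter), a modest shift that came from ethyl replacing chloro on an aromatic carbon. This is a limited guide, as compound 3 changes more than the group itself. Neither measured compound carries a 4-substituted phenyl, so the data do not test this change directly.

In this assay, a larger, upward move is therefore expected, though with much uncertainty: the estimated step is a 77-fold higher number from compound 2 to compound 3 (1.89 log units; beyond the scatter). The expected value for compound 3 is 500 nM, with an estimated range from 40 nM to 5000 nM.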

Compound 3, half-maximal effective concentration: 540 nM
Compound 3: the middle estimate sits 1.1-fold (0.03 log units) below what was measured; measured number inside the range.
By their numbers in this assay, from the lowest: compound 1; then compound 2; then compound 3.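

In this assay, the swap of ethyl for chloro on the ring at the same site gave only a 2.9-fold higher number from compound 1 to compound 2 (0.47 log units; beyond the scatter) and suggested that this saturated ring carbon could accept some change in its aromatic group. The 4-bromophenyl group shows a much larger effect, with an 84-fold higher number from compound 2 to compound 3 (1.92 log units; beyond the scatter) and, against the 2-chlorophenyl group, a 250-fold higher number from compound 1 to compound 3 (2.39 log units; beyond the scatter) as well. Among these three compounds, both 2-substituted phenyl groups therefore give far lower numbers than the 4-bromophenyl group, but no measured property of the compounds accounts for this difference.

Compound 3 differs from compound 1 and compound 2 in both the substituent and its site on the phenyl ring, so these data cannot show whether bromine itself or the shift to the 4-position drives the rise. A 2-bromophenyl or 4-chlorophenyl group would separate those two changes, while an unsubstituted phenyl group would show how much any substituent contributes at all.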